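Changing the ring on the amide nitrogen of a shared core

This account rests on a few compounds, and the source may have more. Where it says the series, first, only, none or still open, it means among the compounds named here.

Compound 1 `O=C(COc1ccc(/C=C2\SC(=O)NC2=O)cc1)Nc1nc2ccccc2s1`: in a functional assay on KB cells (Homo sapiens) for cytotoxicity, read by sulforhodamine B assay, with a stated time of 48 h (on this read-out higher numbers stand for weaker inhibition of growth and lower numbers for stronger inhibition of growth), compound 1 gives < 100000 nM, which is a limit of the assay and not a number.
Compound 2 `O=C(COc1ccc(/C=C2\SC(=O)NC2=O)cc1)Nc1ncc([N+](=O)[O-])s1`: in this assay compound 2 gives < 100000 nM, again only a limit.
Compound 3 `O=C1NC(=O)/C(=C\c2ccc(OCC(=O)N3C(=O)c4ccccc4S3(=O)=O)cc2)S1`: in this assay compound 3 gives < 100000 nM, also a limit.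

The three measured compounds share one core and differ only in the group carried on the amide. None of them has yielded a number: the limit of < 100000 nM in this assay, at which 3 of the 3 values shown sit. Compound 2 therefore stands at the limit, indistinguishable from the other two on the figures shown. Within the data shown here, the only step between two compounds that differ in one place, a step that the two limits leave unreadable from compound 1 to compound 2, cannot be sized, because both of its ends are limits.

Compound 4 `Cc1cc(NC(=O)COc2ccc(/C=C3\SC(=O)NC3=O)cc2)no1` is the next member: 5-methyl-1,2-oxazol-3-yl in place of 5-nitro-1,3-thiazol-2-yl on an amide-type nitrogen. Among the measured compounds shown here, no measured step gives a readable size for a change of this kind, so there is no basis for expecting a shift in this assay in either direction beyond the scatter. The change expected is a step that the limit leaves unreadable from compound 2 to compound 4, that is, nothing resolvable. Compound 4 is accordingly expected to come out around 50000 nM, within a range from 5000 nM to 100000 nM, and most likely to be reported, like its precursors, as a limit rather than a number.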

Compound 4, concentration for 50% growth inhibition: < 100000 nM
Compound 4 ended at the assay's limit; the forecaster's own chance of this, stated with the estimate: 75%; the middle value does not contradict the limit.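

The steps from compound 1 to compound 4 and from compound 2 to compound 4 cannot be read, because each of these compounds carries only a limit and not a number: the limit of < 100000 nM in this assay, at which 4 of the 4 values shown sit.

The compounds shown leave open how strongly any of them inhibits growth, and whether changing the group on the amide nitrogen alters that at all.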